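Swapping hydrogen for a sulfur-bearing chain on a smaller core

A few compounds are considered here, and "the series" means these few. Any claim that something is new, unique, unknown or untested is made for them only; others in the source may bear on it.

Measured compounds:
compound 1 `CSCC[C@H](NC1=CC(=O)C=C(C[C@]2(C)[C@@H](C)CC[C@]3(C)C(C)=CCC[C@@H]23)C1=O)C(=O)O` gives 25600 nM in a functional assay on MDA-MB-453 cells (Homo sapiens) for cytotoxicity, read by MTT assay, with a stated time of 72 h; a higher number here means a weaker inhibitor, a lower number a stronger inhibitor;
compound 2 `CC1=CCC[C@H]2[C@](C)(CC3=CC(=O)C=C(N[C@@H](C)C(=O)O)C3=O)[C@@H](C)CC[C@]12C` gives 14700 nM in this assay;
compound 3 `C[C@H](NC1=CC(=O)C=C(C(C)(C)C)C1=O)C(=O)O` gives 112000 nM in this assay.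

Compound 3 has the highest number of the three. Compound 4 `CSCC[C@H](NC1=CC(=O)C=C(C(C)(C)C)C1=O)C(=O)O` has not been measured. Compound 4 differs from compound 3 by (methylsulfanyl)methyl in place of hydrogen on a saturated chain carbon, two bonds along the chain from an amine nitrogen and a carbonyl carbon. The same change, ((methylsulfanyl)methyl in place of hydrogen on a saturated chain carbon, two bonds along the chain from an amine nitrogen and a carbonyl carbon), links compound 2 to compound 1 and produced a 1.7-fold higher number from compound 2 to compound 1 (0.24 log units; within the scatter). The difference between the core of compound 3 and the core of compound 2 is not broken down here.

Because the step of a 1.7-fold higher number from compound 2 to compound 1 (0.24 log units; within the scatter) was small, compound 4 is expected to sit near compound 3, with a step of about a 1.3-fold higher number from compound 3 to compound 4 (0.13 log units; within the scatter). The estimate for compound 4 is 150000 nM, within a range from 60000 nM to 400000 nM.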

Compound 4, half-maximal inhibitory concentration: 151000 nM
Compound 4: middle estimate off by 1.0-fold (0.00 log units), on the low side; low and high end bracket the measured number.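

In this assay, (methylsulfanyl)methyl in place of hydrogen on the saturated chain carbon gives a 1.3-fold higher number from compound 3 to compound 4 (0.13 log units; within the scatter), a small step. The earlier step on the other core was also small, and the two cannot be told apart: the same change on two cores in this assay, a 1.7-fold higher number (0.24 log units; within the scatter) from compound 2 to compound 1 and a 1.3-fold higher number (0.13 log units; within the scatter) from compound 3 to compound 4, 1.3-fold (0.11 log units) apart, within the scatter of two such steps. This shows that the change carried over between these two cores without a detectable difference, but two pairs, each within the scatter, do not show that it would behave the same way on a third core, nor do they explain why the effect is small.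

The compounds shown leave open what a different group at this same carbon would do, such as an amine or a longer chain. They also leave open whether such a group would give a step beyond the scatter on either core.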